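The source may report more compounds than this note shows. Statements on the series, on what has been measured and on what is new or still open speak of the compounds shown alone.

Compound 1 `CCCCOC(=O)NS(=O)(=O)c1sc(CC(C)C)cc1-c1ccc(Cc2ncco2)cc1`: 3.9 nM in an assay on membranes from uterus for displacement of a labelled ligand from Angiotensin type II receptor (Sus scrofa), with a stated time of 1.5 h; a lower number here means a stronger inhibitor, a higher number a weaker inhibitor
Compound 2 `CCCCOC(=O)NS(=O)(=O)c1sc(CC(C)C)cc1-c1ccc(CN2CCCC2=O)cc1`: 3.5 nM in this assay

Compound 1 carries the highest of the two numbers shown, yet its nearest neighbour is compound 2, and the step of a 1.1-fold lower number from compound 1 to compound 2 (0.05 log units; within the scatter) lies within the scatter. Compound 3 `CCCCOC(=O)NS(=O)(=O)c1sc(CC(C)C)cc1-c1ccc(Cn2ccc(C(F)(F)F)n2)cc1` differs from compound 1 by 3-(trifluoromethyl)-1H-pyrazol-1-yl in place of 1,3-oxazol-2-yl on a saturated chain carbon bound to an aromatic carbon. Among the compounds with values here, the one measured step that bears on this change, a 1.1-fold lower number from compound 1 to compound 2 (0.05 log units; within the scatter), exchanged a group at the same saturated chain carbon and stayed within the scatter, so no step beyond the scatter is expected here either. Compound 3 is therefore estimated at 4.5 nM, with a range from 1.5 nM to 14 nM, which means an expected step of a 1.2-fold higher number from compound 1 to compound 3 (0.06 log units; within the scatter).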

Compound 3, inhibition constant: 9.5 nM
Compound 3: middle estimate off by 2.1-fold (0.32 log units), on the low side, within the range that was stated.
By their numbers in this assay, from the lowest: compounds 2 and 1 (each within the scatter of the next); then compound 3.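

In this assay the group on this saturated chain carbon now proves not to be interchangeable: 3-(trifluoromethyl)-1H-pyrazol-1-yl brings a 2.4-fold higher number from compound 1 to compound 3 (0.39 log units; beyond the scatter) and also a 2.7-fold higher number from compound 2 to compound 3 (0.43 log units; beyond the scatter) for the exchange against 2-oxopyrrolidin-1-yl. Both steps are modest, so the change weakens binding only slightly, yet it separates compound 3 from the two earlier compounds. No evidence is available that accounts for this shift. Going by these compounds, what an unsubstituted 1H-pyrazol-1-yl would give stays open, and with it whether the step follows the ring or the trifluoromethyl group. On these data alone, the effect of an amine on this carbon also remains open.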